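Cyano in place of nitro: working notes on toxicity

This account rests on a few compounds, and the source may have more. Where it says the series, first, only, none or still open, it means among the compounds named here.

Measured in a toxicity assay on THP-1 cells (Homo sapiens) for inhibition; on this read-out lower numbers stand for higher toxicity in this test and higher numbers for lower toxicity in this test:
- compound 1 `Cn1c(-c2ccc(Br)cc2)cnc1NC(=O)c1ccc(F)cc1` gives 46000 nM
- compound 2 `Cn1c(-c2ccc(C#N)cc2)cnc1NC(=O)c1ccc(F)cc1` gives > 50000 nM, a limit of the assay
- compound 3 `Cn1c(-c2cccc([N+](=O)[O-])c2)cnc1NC(=O)c1ccc(F)cc1` gives > 50000 nM, a limit of the assay

Compound 3 has no number of its own, only the limit > 50000 nM. Compound 2 also reports only a limit, > 50000 nM. The readings so far therefore gather at the top of the range: the limit of > 50000 nM in this assay, at which 2 of the 3 values shown sit. Only compound 1 has a true number, 46000 nM.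

Next in the series is compound 4 `Cn1c(-c2cccc(C#N)c2)cnc1NC(=O)c1ccc(F)cc1`. The change is cyano in place of nitro on an aromatic carbon, meta to a large group. For the measured compounds named here, one measured step bears on it, also with cyano entering: an at least 1.0-fold higher number from compound 1 to compound 2 (0.03 log units; that floor lies within the scatter). That step has cyano in place of bromo, not nitro, so it is only indirect support, and it shows no change beyond the scatter. No shift beyond the scatter is therefore expected in this assay, and another limit reading is the likeliest result. The expected size of the step is a step that the limit leaves unreadable from compound 3 to compound 4. The estimate for compound 4 is 60000 nM, with an expected range of 30000 nM to 120000 nM.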

Compound 4, half-maximal cytotoxic concentration: > 100000 nM
Compound 4: no number, only a limit; the forecaster's own chance of this, stated with the estimate: 80%; middle value at least 1.6-fold (0.22 log units) from the limit.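

Cyano in place of nitro, meta to a large group, leaves compound 4 with only a limit in this assay, and that limit sits apart from the others: the limit of > 100000 nM in this assay, at which 1 of the 4 values shown sits.

For the compounds shown here, the one readable comparison is an at least 2.1-fold higher number from compound 1 to compound 4 (0.33 log units; beyond the scatter), which lies beyond the scatter, but it exchanges 4-bromophenyl for 3-cyanophenyl and so does not isolate the change from nitro to cyano.

The steps to compound 4 from compound 2 and from compound 3 cannot be read, so neither the exchange of nitro for cyano nor the exchange of 4-cyanophenyl for 3-cyanophenyl has a size, and compound 2 and compound 3 stay at the other limit: the limit of > 50000 nM in this assay, at which 2 of the 4 values shown sit.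

Among the compounds shown, only compound 1 carries a true number, 46000 nM, so the order of compound 2, compound 3 and compound 4 remains unresolved. Also open, going by these compounds, is whether an amine or a carboxylic acid on the same aromatic carbon, meta to a large group, would give a true number in this assay.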